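The source may report more compounds than this note shows. Statements on the series, on what has been measured and on what is new or still open speak of the compounds shown alone.

The measured compounds are:
compound 1, `Cc1ncccc1Oc1ccc(-c2ccn(CCC(C)C)c(=O)c2C#N)cc1`, 256% in a functional assay on CHO cells for positive allosteric modulation of metabotropic glutamate receptor 2 (Homo sapiens), read by scintillation counting and GTPgammaS binding, with a stated time of 30 min; on this read-out higher numbers stand for larger maximal responses and lower numbers for smaller maximal responses
compound 2, `CCCCn1ccc(-c2ccc(Oc3ccc(C)nc3C)cc2)c(C#N)c1=O`, 239% in this assay

Compound 2 stands lowest of the two numbers in this assay; its nearest neighbour is compound 1, which gives the higher value, and that gap lies beyond the usual scatter. Compound 1 and compound 2 differ in more than one place. Nothing can be read from them about any single change.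

Compound 3, `Cc1ccc(Oc2ccc(-c3ccn(CCC(C)C)c(=O)c3C#N)cc2)c(C)n1`, has not yet been measured. It differs from compound 2 in one place: methyl in place of hydrogen on a saturated chain carbon bound to two saturated chain carbons. Cut one bond further out, the same change reads butyl to isopentyl. Within the data shown here, no step of this kind is known among the measured compounds, so the expectation rests on the narrow spread of the two values seen so far: a small step is expected, with an upward lean that may stay within the scatter. Compound 3 is expected to give about 248% in this assay, with a likely range from 215% to 280%. The expected step of a number 9 percentage points higher from compound 2 to compound 3 (within the scatter) is therefore modest.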

Compound 3, largest response reached (Emax), in percent of the reference or control that the assay uses: 246%
Compound 3: the middle estimate sits 2 percentage points above what was measured; the range from low to high includes it.
By their numbers in this assay, from the lowest: compounds 2, 3 and 1 (each within the scatter of the next, the first and the last beyond it).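

Methyl in place of hydrogen on a saturated chain carbon bound to two saturated chain carbons, which turns butyl into isopentyl, gives a number 7 percentage points higher from compound 2 to compound 3 (within the scatter) in this assay; at this place, then, the added methyl does not measurably separate the two compounds. Methyl in place of hydrogen on an aromatic carbon, the other single change now readable, gives a number 10 percentage points lower from compound 1 to compound 3 (within the scatter), so this pair cannot be told apart either. Nothing measured alongside these values speaks to why either step has this size.

Each change is seen only once, so neither step shows how the same change would behave on a different compound. As far as these compounds go, whether a longer chain, or a chain carrying an amine or a carboxylic acid, would hold the response at this level also stays open.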